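Carbamoyl in Place of Ethyl on the Shared Core

The compounds below may be only part of what the source reports. "The series", "measured", "known", "first", "only" and "open" are said of these compounds alone.

Compound 1 `CCc1cccc(-c2nc3ccccc3[nH]2)n1` gives 41% in a functional assay on the whole organism with Rattus norvegicus as the target, read by paw edema, with a stated time of 3 h, at a dose of 100 mg/kg by the oral route; a lower number here means less inhibition, a higher number more inhibition at the dose given (going by the name of the read-out). Compound 2 `CCCCc1ccc(-c2nc3ccccc3[nH]2)nc1` gives -16%. Compound 3 `OCc1ccc(-c2nc3ccccc3[nH]2)nc1` gives -10%.

Compound 1 stands highest of the three, with compound 3 and compound 2 both well beyond the scatter below it. Compound 4 `NC(=O)c1cccc(-c2nc3ccccc3[nH]2)n1` differs from compound 1 by carbamoyl in place of ethyl on an aromatic carbon. Going by the values given here, the only measured step, a number 6 percentage points higher from compound 2 to compound 3 (within the scatter), swaps one chain for a hydroxy at a different position and stays within the scatter, so it bears only loosely on this change. The data give no clear direction for a carbamoyl, and the expected step of a number 16 percentage points lower from compound 1 to compound 4 (beyond the scatter) is a modest decrease that may fall within the scatter. Compound 4 is therefore estimated at 25%, in the range -5% to 55%.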

Compound 4, a percentage reported as inhibition, in the whole organism at one dose (the size of the read-out at that dose, not a potency): 13%
Estimate against measurement, compound 4: 12 percentage points above; low and high end bracket the measured number.
By their numbers in this assay, from the lowest: compounds 2 and 3 (each within the scatter of the next); then compound 4; then compound 1.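

Going by these compounds alone, at this place, on an aromatic carbon next to the ring nitrogen, this assay gives the first direct reading of a change: carbamoyl in place of ethyl brings a number 28 percentage points lower from compound 1 to compound 4 (beyond the scatter) in this pair. The group here therefore matters, with ethyl the better of the two, while compound 4 at 13% still reads as inhibition. Nothing shown accounts for the size of this step.

On these data alone, whether an amine or a carboxylic acid here would read closer to compound 1 or compound 4 stays open, as does the effect of a longer chain in place of ethyl.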